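Cyano in Place of Hydrogen, Carried Over to a Second Core

The source may hold more compounds than are shown below. What is called first, only, known or untested is meant among the compounds shown, and "the series" means these compounds.

Compound 2 `COc1ccc2c(c1)c(-c1cc(C(F)(F)F)cc(-c3cn(S(=O)(=O)c4ccc(C)cc4)c4ccc(OC)cc34)n1)cn2S(=O)(=O)c1ccc(C)cc1` and compound 1 `COc1ccc2c(c1)c(-c1cc(C(F)(F)F)c(C#N)c(-c3cn(S(=O)(=O)c4ccc(C)cc4)c4ccc(OC)cc34)n1)cn2S(=O)(=O)c1ccc(C)cc1` differ in one place only: cyano in place of hydrogen on an aromatic carbon. In a functional assay on A549 cells (Homo sapiens) for inhibition, tested at 0.1 uM (a lower number here means a weaker effect, a higher number a stronger effect of the compound at the concentration tested), compound 2 gives 16.7%, and compound 1 gives 25%, so that the step is a number 8.3 percentage points higher from compound 2 to compound 1 (within the scatter). Compound 3 `Cc1ccc(S(=O)(=O)n2cc(-c3cc(C(F)(F)F)cc(-c4cn(S(=O)(=O)c5ccc(C)cc5)c5cc(Br)ccc45)n3)c3ccc(Br)cc32)cc1` rests on a different core; the difference between the two cores is not broken down here. In this assay compound 3 gives 25.8%, a number that lies within the scatter of both compound 1 and compound 2. Compound 4 `Cc1ccc(S(=O)(=O)n2cc(-c3cc(C(F)(F)F)c(C#N)c(-c4cn(S(=O)(=O)c5ccc(C)cc5)c5cc(Br)ccc45)n3)c3ccc(Br)cc32)cc1` has not been measured yet and arises from compound 3 by the same change as before: cyano in place of hydrogen on an aromatic carbon. For the measured compounds named here, the only guide to its effect is the earlier pair, where the change gave a number 8.3 percentage points higher from compound 2 to compound 1 (within the scatter), a step within the scatter. Compound 4 is therefore expected to show a step of a number 6.2 percentage points higher from compound 3 to compound 4 (within the scatter), of a size close to that earlier step, resting on a single precedent. Compound 4 is estimated to give 32% in this assay, with a likely range from 18% to 46%.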

Compound 4, a percentage reported as inhibition, at one concentration (the size of the read-out at that concentration, not a potency): 23.8%
Compound 4: the middle estimate sits 8.2 percentage points above what was measured, within the range that was stated.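

On the core of compound 3, cyano in place of hydrogen on an aromatic carbon gives, in this assay, a step that is a number 2 percentage points lower from compound 3 to compound 4 (within the scatter). Set beside the earlier pair, the two steps cannot be told apart: the same change on two cores in this assay, a number 8.3 percentage points higher (within the scatter) from compound 2 to compound 1 and a number 2 percentage points lower (within the scatter) from compound 3 to compound 4, 10.3 percentage points apart, within the scatter of two such steps. This shows that on neither core does the change move the read-out beyond the scatter, and that the two cores give no sign of answering to it differently; it does not show that the change has no effect or that any effect carries over unchanged, for the evidence is two small steps, from two pairs, at a single concentration.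

The compounds shown leave open whether another group on the same aromatic carbon, such as an amine, a carboxylic acid or a methyl group, would give a step beyond the scatter on either core. They also leave open how these two pairs compare at other concentrations, where the effect could be stronger or weaker.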